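Series notes: piperidine substituent swap from compound 3 to compound 4

The source may hold more compounds than are shown below. What is called first, only, known or untested is meant among the compounds shown, and "the series" means these compounds.

Three compounds share the core seen in compound 1 `O=C(CCN1CCC(c2cc[nH]n2)CC1)N1CCC[C@H]1c1nc2cc(Cl)c(Cl)cc2[nH]1` and differ only in the group on a saturated ring carbon of the piperidine. In an assay on a cell-free system (plasma) for inhibition of lysosomal Pro-X carboxypeptidase (Mus musculus) (on this read-out lower numbers stand for stronger inhibition and higher numbers for weaker inhibition), compound 1 gives 290 nM. Compound 2 `O=C(CCN1CCC(n2ncnn2)CC1)N1CCC[C@H]1c1nc2cc(Cl)c(Cl)cc2[nH]1` gives 2900 nM, and compound 3 `O=C(CCN1CCC(c2nc(-c3cnccn3)no2)CC1)N1CCC[C@H]1c1nc2cc(Cl)c(Cl)cc2[nH]1` gives 435 nM. Compound 3 stands second highest of the three numbers: the step of a 1.5-fold higher number from compound 1 to compound 3 (0.18 log units; within the scatter) is within the scatter, whereas a 6.7-fold lower number from compound 2 to compound 3 (0.82 log units; beyond the scatter) is a modest gain and a 10-fold higher number from compound 1 to compound 2 (1.00 log units; beyond the scatter) a modest loss.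

Compound 4 `Cn1nc(C2CCN(CCC(=O)N3CCC[C@H]3c3nc4cc(Cl)c(Cl)cc4[nH]3)CC2)cc1-c1cccnc1` has not been measured. It differs from compound 3 by a group of 12 heavy atoms (9 carbon, 3 nitrogen; one five-membered aromatic ring with 2 hetero atoms, one six-membered aromatic ring with 1 hetero atom) in place of a group of 11 heavy atoms (6 carbon, 4 nitrogen, 1 oxygen; one five-membered aromatic ring with 3 hetero atoms, one six-membered aromatic ring with 2 hetero atoms), on a saturated ring carbon. Going by the values given here, two measured steps bear on this position. Replacing a five-membered aromatic ring with 2 hetero atoms by the larger two-ring group in compound 3 left the number essentially unchanged, as a 1.5-fold higher number from compound 1 to compound 3 (0.18 log units; within the scatter) shows; only the ring with 4 hetero atoms in compound 2 weakened inhibition. Compound 4 again carries a five-membered ring with 2 hetero atoms, now extended by a six-membered ring with 1 hetero atom, which resembles both compound 1 and compound 3 more than compound 2. The step of a 1.2-fold lower number from compound 3 to compound 4 (0.09 log units; within the scatter) is therefore expected to stay within the scatter. Compound 4 is estimated at 350 nM in this assay, with a range from 150 nM to 900 nM.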

Compound 4, half-maximal inhibitory concentration: 39 nM
For compound 4 the middle estimate is 9.0-fold (0.95 log units) above the measured one; measured number below the stated range.
By their numbers in this assay, from the lowest: compound 4; then compounds 1 and 3 (each within the scatter of the next); then compound 2.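

In this assay, two two-ring groups of similar size on the saturated ring carbon are not interchangeable: the group of 12 heavy atoms replacing the group of 11 heavy atoms gives an 11-fold lower number from compound 3 to compound 4 (1.05 log units; beyond the scatter) and is a large step. Going by these compounds alone, compound 3 had suggested that extending the group gains nothing over the single ring of compound 1, but compound 4 goes the other way, with a 7.4-fold lower number from compound 1 to compound 4 (0.87 log units; beyond the scatter) showing that a two-ring group at this position can beat the single ring, so compound 3 is the exception to any link between a larger group and a lower number. The span seen at this position also widens, with a 74-fold lower number from compound 2 to compound 4 (1.87 log units; beyond the scatter) as the largest step in the series, and no measurement shown here gives a reason for the gain.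

The five-membered and six-membered aromatic rings change together from compound 3 to compound 4, so their separate contributions cannot be told apart. From the compounds shown here alone, whether a phenyl ring, with carbon in place of the ring nitrogen of the six-membered ring, or a carboxylic acid on that ring would keep the number this low remains open.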